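Swapping trifluoromethyl for chloro on the urea aryl ring

The source may hold more compounds than are shown below. What is called first, only, known or untested is meant among the compounds shown, and "the series" means these compounds.

Measured compounds:
compound 1 `COc1cc2cc(Oc3ccc(NC(=O)Nc4cccc(C(F)(F)F)c4)cc3)c(C)nc2cc1OC` gives 2060 nM
compound 2 `COc1cc2cc(Oc3ccc(NC(=O)Nc4ccc(Cl)c(C(F)(F)F)c4)cc3)c(C)nc2cc1OC` gives 1350 nM

Both numbers come from a functional assay on SK-OV-3 cells (Homo sapiens) for inhibition, read by sulforhodamine B assay, with a stated time of 48 h; a higher number here means a weaker inhibitor of growth, a lower number a stronger inhibitor of growth. Compound 2 holds the lower of the two values, but the step of a 1.5-fold lower number from compound 1 to compound 2 (0.18 log units; within the scatter) is too small to call a real difference, so the two compounds stand level. Compound 3 `COc1cc2cc(Oc3ccc(NC(=O)Nc4ccc(Cl)c(Cl)c4)cc3)c(C)nc2cc1OC` has not been tested. It differs from compound 2 by chloro in place of trifluoromethyl on an aromatic carbon. Within the data shown here, no measured pair shows this exchange directly; the one step recorded, adding a chloro next to the trifluoromethyl, changed nothing beyond the scatter. With only that to go on, the expected step of a 1.1-fold higher number from compound 2 to compound 3 (0.05 log units; within the scatter) is small and without a clear direction. Compound 3 is therefore estimated at 1500 nM, with a range from 500 nM to 4500 nM in this assay.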

Compound 3, concentration for 50% growth inhibition: 7560 nM
Compound 3: the middle estimate sits 5.0-fold (0.70 log units) below what was measured, and the stated range ends below it.
By their numbers in this assay, from the lowest: compounds 2 and 1 (each within the scatter of the next); then compound 3.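

This position turns out to be sensitive in this assay: chloro in place of trifluoromethyl gives a 5.6-fold higher number from compound 2 to compound 3 (0.75 log units; beyond the scatter) and so moves the number beyond the scatter, which the earlier addition of a chloro group to the same ring did not do. The 3,4-dichlorophenyl group also falls short of the 3-(trifluoromethyl)phenyl group, with a 3.7-fold higher number from compound 1 to compound 3 (0.56 log units; beyond the scatter) in the same direction, so among these three compounds the two with trifluoromethyl stand level and the one without it has the weakest growth inhibition. Nothing measured here accounts for this loss.

The compounds shown leave open how a nitrile or a methyl group would behave at this position. They also leave open whether chloro in place of trifluoromethyl on compound 1, with no second chloro on the ring, would cost as much.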